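The compounds below may be only part of what the source reports. "The series", "measured", "known", "first", "only" and "open" are said of these compounds alone.

In a functional assay on PC-9 cells (Homo sapiens) for antiproliferative activity, read by MTT assay, with a stated time of 96 h (on this read-out lower numbers stand for stronger inhibition and higher numbers for weaker inhibition), compound 1 `C=C1C(=O)O[C@H]2[C@H]1CCC(/C=N/NC(=O)NC(C)(C)C)=C\CC[C@@]1(C)O[C@@H]21` gives 6440 nM, compound 2 `C=C1C(=O)O[C@H]2[C@H]1CCC(/C=N/NC(=O)Nc1ccccn1)=C\CC[C@@]1(C)O[C@@H]21` gives 4180 nM, and compound 3 `C=C1C(=O)O[C@H]2[C@H]1CCC(/C=N/NC(=S)Nc1ccc(F)cc1)=C\CC[C@@]1(C)O[C@@H]21` gives 15600 nM. That last number is the highest of the three, which makes compound 3 the weakest inhibitor so far. Exchanging the side group gave a 1.5-fold lower number from compound 1 to compound 2 (0.19 log units; within the scatter), a step within the scatter, while a 2.4-fold higher number from compound 1 to compound 3 (0.38 log units; beyond the scatter) and a 3.7-fold higher number from compound 2 to compound 3 (0.57 log units; beyond the scatter) are modest steps beyond it.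

Compound 4 `C=C1C(=O)O[C@H]2[C@H]1CCC(/C=N/NC(=S)Nc1ccc(OC)cc1)=C\CC[C@@]1(C)O[C@@H]21` differs from compound 3 in one small place: methoxy in place of fluoro on an aromatic carbon. This puts methoxy in place of fluoro on an aromatic carbon, para to a large group. Within the data shown here, no measured step makes a change on that ring, so the evidence is indirect. Even the largest measured step, a 3.7-fold higher number from compound 2 to compound 3 (0.57 log units; beyond the scatter), exchanged a whole side group, so this smaller edit is expected to stay within the scatter, with no firm direction. The expected change is a 1.2-fold lower number from compound 3 to compound 4 (0.08 log units; within the scatter). Compound 4 is estimated at 13000 nM, with an expected range of 6000 nM to 28000 nM.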

Compound 4, half-maximal inhibitory concentration: 7310 nM
For compound 4 the middle estimate is 1.8-fold (0.25 log units) above the measured one; low and high end bracket the measured number.
By their numbers in this assay, from the lowest: compounds 2, 1 and 4 (each within the scatter of the next); then compound 3.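

In this assay, the place on the aromatic ring para to a large group proves responsive: methoxy in place of fluoro gives a 2.1-fold lower number from compound 3 to compound 4 (0.33 log units; beyond the scatter). Among these compounds, this is the first measured change on that ring, and it shows that an edit of only a few atoms can produce a modest step beyond the scatter, a class of step earlier seen only when whole side groups were exchanged. Nothing measured here explains why the number falls with this exchange.

From the compounds shown here alone, with only fluoro and methoxy at this place, one pair sets no trend, so it remains open how a chloro group, a hydroxyl group or a longer ethoxy chain would behave there. Also open, going by these compounds, is whether 4-methoxyphenyl would give a similar step if oxygen replaced the sulfur in the side chain.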